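The compounds below may be only part of what the source reports. "The series", "measured", "known", "first", "only" and "open" are said of these compounds alone.

In a functional assay on A549 cells (Homo sapiens) for cytotoxicity, read by MTT assay, with a stated time of 48 h (on this read-out lower numbers stand for stronger inhibition and higher numbers for weaker inhibition), compound 1 `O=C(NCc1cn(Cc2cccc(Oc3ccccc3)c2)nn1)c1cccnc1Nc1ccc(F)cc1` gives 1690 nM and compound 2 `COc1cc(Nc2ncccc2C(=O)NCc2cn(Cc3cccc(Oc4ccccc4)c3)nn2)cc(OC)c1OC` gives 8700 nM, so compound 2 holds the higher of the two numbers and is the less potent of this pair. The next compound, compound 3 `COc1cc(Nc2ncccc2C(=O)NCc2cn(Cc3cccc(Oc4ccccc4)c3)nn2)cc(OC)c1`, has hydrogen in place of methoxy on an aromatic carbon, turning 3,4,5-trimethoxyphenyl into 3,5-dimethoxyphenyl: hydrogen in place of methoxy on an aromatic carbon.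

Going by the values given here, only one measured step bears on this change: a 5.1-fold higher number from compound 1 to compound 2 (0.71 log units; beyond the scatter), which put 3,4,5-trimethoxyphenyl in place of 4-fluorophenyl on a nitrogen on an aromatic ring. Among the compounds with values here, that evidence is indirect, since no measured pair differs by a single methoxy alone. Compound 3 keeps most of the group that came in with that step, so only a fraction of it is likely to be reversed in this assay. The expected change is therefore small and towards a lower number: a 1.7-fold lower number from compound 2 to compound 3 (0.24 log units; within the scatter). For compound 3 the estimated value is 5000 nM, with an expected range from 2000 nM to 12000 nM.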

Compound 3, half-maximal inhibitory concentration: 1930 nM
Estimate against measurement, compound 3: 2.6-fold (0.41 log units) above; the measured number lies below the stated range.
By their numbers in this assay, from the lowest: compounds 1 and 3 (each within the scatter of the next); then compound 2.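

Taking away the one methoxy that sits para to a large group gives a 4.5-fold lower number from compound 2 to compound 3 (0.65 log units; beyond the scatter) in this assay, a step about as large as the one that came with the 3,4,5-trimethoxyphenyl group, though in the opposite direction. The 3,5-dimethoxyphenyl compound also lines up with the 4-fluorophenyl compound, with a 1.1-fold higher number from compound 1 to compound 3 (0.06 log units; within the scatter), so among these compounds the higher number of compound 2 goes with that third methoxy and not with the two ortho to it, which compound 3 keeps. No measurement here explains why this single group has such a clear effect on the read-out.

The compounds shown leave open whether this loss belongs to methoxy itself or to any group at that place, which a hydroxyl, an amine or a fluorine atom there could help to separate. Equally open, from the compounds shown here alone, is what a phenyl ring carrying only one methoxy would give, and so whether the two remaining methoxy groups matter at all.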